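This account rests on a few compounds, and the source may have more. Where it says the series, first, only, none or still open, it means among the compounds named here.

Measured so far:
compound 1 `COc1ccccc1-n1nc(C)c2c1NC(=O)[C@H](C)S[C@@H]2c1ccc(Oc2ccccc2)cc1` — 3300 nM
compound 2 `COc1ccc(Oc2ccc([C@H]3S[C@@H](C)C(=O)Nc4c3c(C)nn4-c3ccccc3C)cc2)cc1` — 2200 nM

In an assay on isolated protein for agonist activity at Bile acid receptor (Homo sapiens), read by AlphaScreen, with a stated time of 30 min (on this read-out lower numbers stand for an effect already at smaller amounts and higher numbers for an effect only at larger amounts of compound), compound 1 gives 3300 nM and compound 2 gives 2200 nM. Compound 2 shows the lower of the two numbers, but its gap to compound 1 lies within the scatter, so the two cannot be separated on this read-out; both sit in the weak range.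

Compound 3 `Cc1ccccc1-n1nc(C)c2c1NC(=O)[C@H](C)S[C@@H]2c1ccc(-c2ccccc2)cc1` has not yet been run in this assay. It differs from compound 2 in one place: phenyl in place of 4-methoxyphenoxy on an aromatic carbon. Within the data shown here, no step between measured compounds covers a change of this kind, so the expectation rests on the two values alone, and those two, differing only in the outer part of the same aromatic substituent, do not show that this part drives the read-out. A step of no more than the scatter, in either direction, is expected, a 1.4-fold higher number from compound 2 to compound 3 (0.13 log units; within the scatter). Compound 3 is estimated at 3000 nM, with a range from 1000 nM to 10000 nM.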

Compound 3, half-maximal effective concentration: 990 nM
Compound 3: the middle estimate sits 3.0-fold (0.48 log units) above what was measured; measured number below the stated range.
By their numbers in this assay, from the lowest: compound 3; then compounds 2 and 1 (each within the scatter of the next).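

In this assay, phenyl in place of 4-methoxyphenoxy on an aromatic carbon, para to a large group, gives a 2.2-fold lower number from compound 2 to compound 3 (0.35 log units; beyond the scatter). This is the only step shown that lies beyond the scatter, so the outer part of this substituent does affect the read-out, and the 4-methoxyphenoxy group, with its larger heavy-atom count and two hydrogen-bond acceptors, is not required for activity at this position. No supporting data bear on which feature of the change accounts for the step.

A plain phenoxy group in this place would separate the contribution of the linking oxygen from that of the methoxy, while an amine or a carboxylic acid on the outer phenyl would test how far this ring tolerates substitution. On these data alone, whether the step carries over to the aryl group of compound 1 also remains open.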